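The source may hold more compounds than are shown below. What is called first, only, known or untested is meant among the compounds shown, and "the series" means these compounds.

Measured so far:
compound 1 `Cc1cccnc1-c1ccc(C(=O)Nc2ccc(C(C)(C)C)cc2)cc1` — 11 nM
compound 2 `CC(C)(C)c1ccc(NC(=O)c2ccc(-c3ncccc3C(=O)O)cc2)cc1` — > 4000 nM

In a functional assay for antagonist activity at transient receptor potential cation channel subfamily V member 1 (Homo sapiens), read by FLIPR (a lower number here means a stronger inhibitor, a higher number a weaker inhibitor), compound 1 gives 11 nM. For compound 2 the assay reports only a limit, > 4000 nM, so compound 2 stands at the weak end of the two values (the limit of > 4000 nM in this assay, at which 1 of the 2 values shown sits). For the measured compounds named here, the single measured step, an at least 360-fold higher number from compound 1 to compound 2 (2.56 log units; beyond the scatter), is large. Compound 3 `CC(C)(C)c1ccc(NC(=O)c2ccc(-c3ncccc3-c3ncc[nH]3)cc2)cc1` differs from compound 2 by 1H-imidazol-2-yl in place of carboxy on an aromatic carbon. That step removes the carboxy whose arrival gave an at least 360-fold higher number from compound 1 to compound 2 (2.56 log units; beyond the scatter), so a lower number than the limit of compound 2 is expected, though not a return to compound 1, which differs from compound 3 as well. Compound 3 is therefore estimated at 200 nM (range 30 nM to 2000 nM), an expected step of an at least 20-fold lower number from compound 2 to compound 3 (1.30 log units; beyond the scatter).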

Compound 3, half-maximal inhibitory concentration: 3670 nM
Estimate against measurement, compound 3: 18-fold (1.26 log units) below; the measured number lies above the stated range.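

In this assay there is a 330-fold higher number from compound 1 to compound 3 (2.52 log units; beyond the scatter) with 1H-imidazol-2-yl in place of methyl, so the large loss at this position does not belong to carboxy alone. Swapping carboxy for 1H-imidazol-2-yl gives an at least 1.0-fold lower number from compound 2 to compound 3 (0.03 log units; that floor lies within the scatter) as the only figure for that change. Going by these compounds, the value of compound 2 is a limit of the assay, so this figure is a floor and the true size of the step stays unknown.

Still open, on these data alone, is whether a small group such as chloro or methoxy, or an amine, would keep the strength of compound 1 at this position.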